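The source may report more compounds than this note shows. Statements on the series, on what has been measured and on what is new or still open speak of the compounds shown alone.

In a functional assay on CHO cells for agonist activity at adenosine receptor A1 (Homo sapiens), read by fluorescence and ERK phosphorylation, with stated times of 30 min and 1.5 h, tested at 3 uM (on this read-out lower numbers stand for a weaker effect and higher numbers for a stronger effect at the one concentration tested), three compounds have been measured:

Compound 1, `Nc1scc(-c2ccc([N+](=O)[O-])cc2)c1C(=O)c1ccccc1`, gives 50%.
Compound 2, `COc1ccc(-c2csc(N)c2C(=O)c2ccccc2)cc1`, gives 52%.
Compound 3, `Nc1scc(-c2cccc([N+](=O)[O-])c2)c1C(=O)c1ccc(Cl)cc1`, gives 53%.

Compound 1 and compound 2 differ in a single place: methoxy in place of nitro on an aromatic carbon. In this assay that change gave a number 2 percentage points higher from compound 1 to compound 2 (within the scatter). Compound 3 is built on a different core than compound 1; the difference between the two cores is not broken down here. Compound 3 and compound 2 lie within the scatter of each other, as do compound 3 and compound 1, so no order among the three can be read from these numbers.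

Compound 4, `COc1cccc(-c2csc(N)c2C(=O)c2ccc(Cl)cc2)c1`, has not yet been measured. It is made from compound 3 by the change (methoxy in place of nitro on an aromatic carbon). For the measured compounds named here, this is the same kind of change as the one from compound 1 to compound 2, not the same one: in compound 2 the methoxy sits para to a large group, whereas in compound 4 it sits meta to a large group.

For compound 4 a step of a number 2 percentage points higher from compound 3 to compound 4 (within the scatter) is expected, because the earlier example of this kind of change was a number 2 percentage points higher from compound 1 to compound 2 (within the scatter). In this assay compound 4 is therefore estimated at 55%, and it is expected to fall between 42% and 66%.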

Compound 4, a percentage reported as activity, at one concentration (the size of the read-out at that concentration, not a potency): 58%
Beside the measured number, compound 4's estimate is 3 percentage points below it, and the stated range covers the measured number.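

In this assay, putting methoxy in place of nitro gave a number 5 percentage points higher from compound 3 to compound 4 (within the scatter). Set beside the same change on the other core, the two steps do not differ: the same change on two cores in this assay, a number 2 percentage points higher (within the scatter) from compound 1 to compound 2 and a number 5 percentage points higher (within the scatter) from compound 3 to compound 4, 3 percentage points apart, within the scatter of two such steps. This shows that the change behaves alike on these two cores, in that neither step stands out from the usual scatter, but it does not show that methoxy truly raises the number compared with nitro, and two cores are too few to support a rule for the whole series.

On these data alone, it remains open whether another group in place of nitro, such as an amine, a carboxylic acid or a longer chain like butoxy, would move the number beyond the scatter. These readings give the size of the effect at a single concentration and leave open what effect any of the four compounds would have at other concentrations.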